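Fluoro in place of tert-butyl: working notes

The source may hold more compounds than are shown below. What is called first, only, known or untested is meant among the compounds shown, and "the series" means these compounds.

Values in a functional assay on MCF7 cells (Homo sapiens) for antiproliferative activity, read by MTT assay, with a stated time of 72 h; on this read-out lower numbers stand for stronger inhibition and higher numbers for weaker inhibition:
- compound 1 `C=C1CN/C(=N/c2ccccc2)S1`: > 100000 nM (a limit of the assay, not a number)
- compound 2 `COc1ccc(/C=C2/CN(C)/C(=N/c3ccc(C(C)(C)C)cc3)S2)cc1`: 28700 nM
- compound 3 `FC(F)(F)c1cc(/N=C2/NC/C(=C/c3ccccc3)S2)cc(C(F)(F)F)c1`: 13500 nM

Of the two true numbers, compound 2 stands higher at 28700 nM. Compound 3 lies lower at 13500 nM, a gap beyond the scatter. Compound 1 gives a limit only.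

Compound 4 `COc1ccc(/C=C2/CN(C)/C(=N/c3ccc(F)cc3)S2)cc1` is not yet measured and differs from compound 2 in one place: fluoro in place of tert-butyl on an aromatic carbon. Fluoro takes the place of tert-butyl on an aromatic carbon of a six-membered aromatic ring of carbon only, para to a large group. Among the measured compounds shown here, no measured pair isolates this change, so the expectation is only loose. In this assay, a small move towards a higher number is expected, possibly none beyond the scatter. The estimated change is a 1.2-fold higher number from compound 2 to compound 4 (0.09 log units; within the scatter). This rests on compound 2 at 28700 nM as the nearest reference. The expected value for compound 4 is 35000 nM, with an estimated range from 12000 nM to 90000 nM.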

Compound 4, half-maximal inhibitory concentration: 8000 nM
Compound 4: middle estimate off by 4.4-fold (0.64 log units), on the high side, outside the stated range (below it).
By their numbers in this assay, from the lowest: compounds 4 and 3 (each within the scatter of the next); then compound 2. At a limit, above all of these: compound 1.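

In this assay, among the compounds shown here, the swap of tert-butyl for fluoro gives a 3.6-fold lower number from compound 2 to compound 4 (0.55 log units; beyond the scatter) and so provides the first single-place reading: the substituent on this aromatic carbon, para to a large group, affects the result. tert-Butyl is not required at this place for activity, since a group of 4 heavy atoms gives way to a single fluorine and the number falls rather than rises. No measurement shown bears on why the number moves.

From the compounds shown here alone, whether the step belongs to fluoro itself or only to the loss of tert-butyl remains open, as does how chloro, an amine or a carboxylic acid would read at this place. Going by these compounds, it is also open whether the same step would hold on a differently substituted core.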